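This account rests on a few compounds, and the source may have more. Where it says the series, first, only, none or still open, it means among the compounds named here.

Working notes on the cyanoguanidine series. Compound 1, `CN/C(=N/C#N)NCCCCc1nc[nH]c1C`, and compound 2, `N#C/N=C(/NCCCCNc1nc(N)n[nH]1)NCCSc1ccccc1`, have both been run in a functional assay on Sf9 cells for antagonist activity at histamine H2 receptor (Homo sapiens), read by scintillation counting and GTPgammaS binding, with a stated time of 90 min; a lower number here means a less potent compound, a higher number a more potent compound, by a factor of ten per unit of this negative logarithm. In this assay compound 1 returns only a limit, < 5. Compound 2 likewise returns only a limit in this assay, < 5. Going by the values given here, compound 2 thus stands at the floor of what has been measured so far; (the limit of < 5 in this assay, at which 2 of the 2 values shown sit), so no numerical value separates it from compound 1, and no step between measured compounds can be drawn.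

The next compound, compound 3, `N#C/N=C(/NCCCNc1ccccn1)NCCSc1ccccc1`, is not yet measured. It differs from compound 2 in a single place: (pyridin-2-yl)amino in place of ((3-amino-1H-1,2,4-triazol-5-yl)amino)methyl on a saturated chain carbon, three bonds along the chain from an amine nitrogen. The cyanoguanidine and the phenylthioethyl arm are retained; only the group at the far end of the chain is exchanged.

With compound 2 sitting at a limit, no direction can be read from the pair itself. Compound 3 is expected to give roughly 5.3 in this assay, within a range of 4.5 to 6.3. The step of a number at least 0.30 log units higher from compound 2 to compound 3 (that floor lies within the scatter) expected here is modest and may still leave compound 3 at the limit.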

Compound 3, negative logarithm of the antagonist equilibrium constant: < 5
Compound 3: a limit, no number (the forecaster's own chance of this, stated with the estimate: 40%); middle value at least 0.30 log units away from the limit.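

No step can be read from compound 2 to compound 3, since each returns only a limit and no number: the limit of < 5 in this assay, at which 3 of the 3 values shown sit.

The compounds shown leave open how far each lies from that limit, and whether exchanging ((3-amino-1H-1,2,4-triazol-5-yl)amino)methyl for (pyridin-2-yl)amino changes the read-out at all.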